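Methoxyphenyl sulfonamides: moving the methoxy group

The compounds below may be only part of what the source reports. "The series", "measured", "known", "first", "only" and "open" are said of these compounds alone.

Compound 1 `CCN(Cc1ccccc1)C(=O)C1CCN(S(=O)(=O)c2ccccc2)CC1` is the unsubstituted parent of the pair. In a functional assay on CHO cells for positive allosteric modulation of muscarinic acetylcholine receptor M5 (Homo sapiens), read by calcium flux (a higher number here means a larger maximal response, a lower number a smaller maximal response), compound 1 gives 69%. Compound 2 `CCN(Cc1ccccc1)C(=O)C1CCN(S(=O)(=O)c2ccc(OC)cc2)CC1` carries a methoxy group on the aromatic ring; in this assay compound 2 gives 84%, a change of a number 15 percentage points higher from compound 1 to compound 2 (beyond the scatter). Compound 2 therefore stands highest of the two numbers measured, with compound 1 the nearest and lower by a margin beyond the scatter.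

Compound 3 `CCN(Cc1ccccc1)C(=O)C1CCN(S(=O)(=O)c2cccc(OC)c2)CC1` differs from compound 2 only in the placement of that group: 3-methoxyphenyl in place of 4-methoxyphenyl on a sulfonyl sulfur. Among the measured compounds shown here, the single measured step that bears on this is the one from compound 1 to compound 2, which shows that a methoxy group on the ring is tolerated and raises the maximal response modestly. For the measured compounds named here, no measured pair shows what moving the group does, so the direction is open and the step is expected to be small, most likely within the scatter.

The expected step from compound 2 to compound 3 in this assay is a number 6 percentage points lower from compound 2 to compound 3 (within the scatter). Compound 3 is estimated at 78%, within a range of 62% to 92%.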

Compound 3, largest response reached (reported as percent of maximum), in percent of the reference or control that the assay uses: 77%
For compound 3 the middle estimate is 1 percentage points above the measured one; measured number inside the range.
By their numbers in this assay, from the lowest: compounds 1, 3 and 2 (each within the scatter of the next, the first and the last beyond it).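

In this assay, the change from 4-methoxyphenyl to 3-methoxyphenyl on a sulfonyl sulfur gives a number 7 percentage points lower from compound 2 to compound 3 (within the scatter), so the two placements of the methoxy group cannot be told apart in this series. Against the unsubstituted parent, the 3-methoxyphenyl group gives a number 8 percentage points higher from compound 1 to compound 3 (within the scatter), which means that compound 3 also cannot be separated from compound 1, and of the two methoxy placements only the 4-methoxyphenyl group in compound 2 stands beyond the scatter from the parent. The methoxy effect on the maximal response is therefore firmly supported for one placement only, while compound 3 sits in the overlap between compound 1 and compound 2, and no available evidence bears on any reason for this.

From the compounds shown here alone, what remains open is whether any other group on this aromatic ring separates from the methoxy compounds, for example a chlorine, an amine, a carboxylic acid or the longer ethoxy chain. The three compounds also share the rest of the core unchanged, so they leave open how far these readings hold once the amide part is altered.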